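Bromo in place of hydrogen on two cores, cytotoxicity

The source may report more compounds than this note shows. Statements on the series, on what has been measured and on what is new or still open speak of the compounds shown alone.

Measured so far in an ADME assay on HEK-293T cells (Homo sapiens) for cytotoxicity, read by luminescence and CellTiter-Glo, with a stated time of 24 h; a higher number here means that more compound is tolerated, a lower number that less compound is tolerated:

compound 1, `CCCNC(=O)C1CCN(C(=O)c2cc3scnc3n2Cc2ccc(OC)cc2)CC1`: 19100 nM
compound 3, `CCCNC(=O)C1CCN(C(=O)c2cc3sc(Br)nc3n2Cc2ccc(OC)cc2)CC1`: 36700 nM
compound 2, `CCCNC(=O)C1CCN(C(=O)c2cccn2Cc2ccc(OC)cc2)CC1`: only a limit, > 100000 nM

Among the measured compounds shown here, the one counted step is bromo in place of hydrogen on an aromatic carbon, which gives a 1.9-fold higher number from compound 1 to compound 3 (0.28 log units; within the scatter). The difference between the core of compound 1 and the core of compound 2 is not broken down here. Compound 2 sits at the limit of > 100000 nM in this assay, at which 1 of the 3 values shown sits, so its value is a limit and not a number.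

Not yet measured is compound 4, `CCCNC(=O)C1CCN(C(=O)c2ccc(Br)n2Cc2ccc(OC)cc2)CC1`. It arises from compound 2 by bromo in place of hydrogen on an aromatic carbon, the same kind of change as from compound 1 to compound 3, but on a different place: in compound 3 the bromo sits on a five-membered aromatic ring with 1 nitrogen and 1 sulfur, part of a fused or bridged system of two rings, next to the ring sulfur; in compound 4 it sits on a five-membered aromatic ring with 1 nitrogen, next to the ring atom that bears a 4-methoxybenzyl group, two ring bonds from the ring atom that bears a large group.

For compound 4 the expected step in this assay is a step that the limit leaves unreadable from compound 2 to compound 4, beside the earlier one, which rests on a 1.9-fold higher number from compound 1 to compound 3 (0.28 log units; within the scatter) and on compound 2 standing at the limit of > 100000 nM in this assay, at which 1 of the 3 values shown sits. Compound 4 is therefore estimated at 120000 nM, between 50000 nM and 300000 nM.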

Compound 4, half-maximal cytotoxic concentration: > 100000 nM
Compound 4 gave a limit, no number (the forecaster's own chance of this, stated with the estimate: 75%); the middle value is on the limit's open side.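

Compound 2 and compound 4 both give a limit and not a number in this assay, so no step can be read between them: the limit of > 100000 nM in this assay, at which 2 of the 4 values shown sit.

The compounds shown leave open whether bromo in place of hydrogen on an aromatic carbon changes the number at all on the core of compound 2, and whether any such change would match the step seen on the core of compound 1.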